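Replacing 2,4-dichlorophenyl in compound 3

The source may hold more compounds than are shown below. What is called first, only, known or untested is meant among the compounds shown, and "the series" means these compounds.

Measured in a functional assay on HT-29 cells (Homo sapiens); on this read-out higher numbers stand for weaker inhibition of growth and lower numbers for stronger inhibition of growth:
- compound 1 `O=S(=O)(/C=C/c1ccc(Br)cc1)Cc1ccc(Nc2ncnc3ccc(Br)cc23)cc1`: 10000 nM
- compound 2 `O=S(=O)(/C=C/c1ccc(C(F)(F)F)cc1F)Cc1ccc(Nc2ncnc3ccc(Br)cc23)cc1`: 100000 nM
- compound 3 `COc1cc2ncnc(Nc3ccc(CS(=O)(=O)/C=C/c4ccc(Cl)cc4Cl)cc3)c2cc1OC`: 6000 nM

Compound 3, at 6000 nM, lies within the scatter of compound 1 and well under compound 2. Compound 4 `COc1cc2ncnc(Nc3ccc(CS(=O)(=O)/C=C/c4ccc(F)cc4)cc3)c2cc1OC` keeps the core of compound 3 and differs in one place: 4-fluorophenyl in place of 2,4-dichlorophenyl on a double-bonded chain carbon bound to a double-bonded chain carbon. For the measured compounds named here, the only measured swap at this place, on another core, was a 10-fold higher number from compound 1 to compound 2 (1.00 log units; beyond the scatter), which is modest but beyond the scatter. That single step shows such a swap can matter, but it sets no firm direction here, so only a small rise is expected, with a wide range. The estimated change is a 1.7-fold higher number from compound 3 to compound 4 (0.22 log units; within the scatter). The estimated value for compound 4 is 10000 nM, with a range of 3000 nM to 40000 nM.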

Compound 4, concentration for 50% growth inhibition: > 100000 nM
Compound 4 was reported as a limit; the forecaster's own chance of this, stated with the estimate: 10%; middle value at least 10-fold (1.00 log units) away from the limit.
By their numbers in this assay, from the lowest: compounds 3 and 1 (each within the scatter of the next); then compound 2.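

In this assay, 4-fluorophenyl in place of 2,4-dichlorophenyl gives an at least 16-fold higher number from compound 3 to compound 4 (1.22 log units; beyond the scatter), a large step on the core of compound 3. Compound 4 stands at a limit of the assay, not at a number: the limit of > 100000 nM in this assay, at which 1 of the 4 values shown sits. This place therefore matters on the core of compound 3 as well as on the core of compound 1, which one step on one core could not show.

Every group shown here is a phenyl ring carrying halogen or trifluoromethyl, so the effect of an amine or a carboxylic acid on that ring stays open. The compounds shown also do not separate the part played by each chlorine of 2,4-dichlorophenyl from that of the fluorine in 4-fluorophenyl.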